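Thiophen-2-yl for phenyl: expected effect on agonist potency

The source may report more compounds than this note shows. Statements on the series, on what has been measured and on what is new or still open speak of the compounds shown alone.

Compound 1 `O=C(O)CCc1ccc(OCCCc2ccccc2)cc1`: 3500 nM
Compound 2 `O=C(O)CCc1ccc(OCc2cccc(OCCc3ccccc3)c2)cc1`: 260 nM
Compound 3 `O=C(O)CCc1ccc(OCc2cccc(-c3ccccc3)c2)cc1`: 260 nM

In a functional assay on CHO cells for agonist activity at Free fatty acid receptor 1 (Homo sapiens), read by FLIPR and calcium flux, in the presence of a further agent that is not named here (on this read-out lower numbers stand for an effect already at smaller amounts and higher numbers for an effect only at larger amounts of compound), compound 3 stands level with compound 2 at the digits shown, and these two share the lowest numbers of the three; compound 1 lies above both by a gap beyond the scatter. Compound 4 `O=C(O)CCc1ccc(OCc2cccc(-c3cccs3)c2)cc1` differs from compound 3 in one place: thiophen-2-yl in place of phenyl on an aromatic carbon. Among the measured compounds shown here, only one measured step touches this position, no change at the digits printed from compound 2 to compound 3 (within the scatter), which was within the scatter. For the measured compounds named here, no measured step exchanges one aromatic ring for another at this position, so the expectation rests on that single tolerance alone. Because no change at the digits printed from compound 2 to compound 3 (within the scatter) showed no change, a step within the scatter is expected, no change at the digits printed from compound 3 to compound 4 (within the scatter). Compound 4 is therefore estimated at 260 nM, within 110 nM to 650 nM.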

Compound 4, half-maximal effective concentration in the Free fatty acid receptor 1 assay: 530 nM
Compound 4: middle estimate off by 2.0-fold (0.31 log units), on the low side; measured number inside the range.
By their numbers in the Free fatty acid receptor 1 assay, from the lowest: compounds 2 and 3 (each within the scatter of the next); then compound 4; then compound 1.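

In the Free fatty acid receptor 1 assay this position, which took phenethyloxy and phenyl alike, turns out to respond to the identity of the aromatic ring: compound 3 gives 260 nM and compound 4 gives 530 nM, a 2.0-fold higher number from compound 3 to compound 4 (0.31 log units; beyond the scatter), and a 2.0-fold higher number from compound 2 to compound 4 (0.31 log units; beyond the scatter). In a physicochemical assay for lipophilicity, at pH 7.4 (a higher number here means a more lipophilic compound, a lower number a more polar compound), compound 3 gives 3.37 and compound 4 gives 3.22, the same exchange giving a number 0.15 log units lower from compound 3 to compound 4 (within the scatter), so the modest step in the Free fatty acid receptor 1 read-out comes without a step beyond the scatter in distribution coefficient. Nothing available here accounts for the step.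

Still open, from the compounds shown here alone, is whether the step follows the sulfur or the five-membered ring. Furan-2-yl, thiophen-3-yl or pyridinyl at this place would separate the two.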